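Extending the Butyl Chain: What Compound 4 May Show

This account rests on a few compounds, and the source may have more. Where it says the series, first, only, none or still open, it means among the compounds named here.

Compound 1 `CCCCC(C#CC(=O)OC)O/C=C/C(=O)OC`: 250 nM
Compound 2 `COC(=O)C#CC(O/C=C/C(=O)OC)C1CCCCC1`: 2500 nM
Compound 3 `COC(=O)C#CC(O/C=C/C(=O)OC)C(C)(C)C`: 1800 nM

In a functional assay on HBL-100 cells (Homo sapiens) for antiproliferative activity, read by sulforhodamine B assay, with a stated time of 48 h (a higher number here means a weaker inhibitor of growth, a lower number a stronger inhibitor of growth), compound 1 gives 250 nM, the lowest of the three numbers, and both its steps to the others lie beyond the scatter. Compound 4 `CCCCCCCCCCC(C#CC(=O)OC)O/C=C/C(=O)OC` differs from it by hexyl in place of hydrogen on a saturated chain carbon, five bonds along the chain from an oxygen on an unsaturated carbon and a triple-bonded carbon, with hexyl in place of hydrogen on the butyl chain. The measured steps bear on this only indirectly: cyclohexyl in place of butyl gave a 10-fold higher number from compound 1 to compound 2 (1.00 log units; beyond the scatter), and tert-butyl in place of butyl gave a 7.2-fold higher number from compound 1 to compound 3 (0.86 log units; beyond the scatter), while a 1.4-fold lower number from compound 2 to compound 3 (0.14 log units; within the scatter) separates those two. Going by the values given here, no measured compound tests a longer open chain, so a smaller step in this assay is expected, leaning towards a higher number and perhaps not beyond the scatter. The expected step is a 1.6-fold higher number from compound 1 to compound 4 (0.20 log units; within the scatter). For compound 4 the estimated value is 400 nM, within an expected range of 100 nM to 1800 nM.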

Compound 4, concentration for 50% growth inhibition: 2200 nM
Beside the measured number, compound 4's estimate is 5.5-fold (0.74 log units) below it; measured number outside the range, above it.
By their numbers in this assay, from the lowest: compound 1; then compounds 3, 4 and 2 (each within the scatter of the next).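

Hexyl in place of hydrogen on the butyl chain gives, in this assay, an 8.8-fold higher number from compound 1 to compound 4 (0.94 log units; beyond the scatter), so at this position an open, unbranched chain can also raise the number, not only the ring of compound 2 or the branched group of compound 3. Of the four groups shown here, butyl gives the lowest number, and compound 1 reads 250 nM. Nothing available here bears on why the longer chain raises the number.

Left open is how the number moves at chain lengths between butyl and the chain of compound 4. From the compounds shown here alone, it is also open whether a shorter chain such as ethyl, or a chain ending in an amine or a carboxylic acid, would keep the number near that of compound 1.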